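This account rests on a few compounds, and the source may have more. Where it says the series, first, only, none or still open, it means among the compounds named here.

Compound 1 `COc1cc(OC)c2sc(-c3ccc(N/C=C\C(=O)c4cc(OC)c(OC)c(OC)c4Br)c(C)c3)nc2c1`: 14700 nM
Compound 2 `COc1cc(OC)c2sc(-c3ccc(N/C=C\C(=O)c4cc(OC)c(OC)c(OC)c4)cc3)nc2c1`: 17800 nM

In a functional assay on HeLa cells (Homo sapiens) for antiproliferative activity, read by sulforhodamine B assay, with a stated time of 48 h (a lower number here means a stronger inhibitor, a higher number a weaker inhibitor), compound 2 and compound 1 stand level, within the usual scatter of each other. Compound 3 `COc1cc(OC)c2sc(-c3ccc(N/C=C\C(=O)c4cc(OC)c(OC)c(OC)c4Br)cc3)nc2c1` is compound 2 with bromo in place of hydrogen on an aromatic carbon. Compound 1 carries this bromo too, along with an extra methyl group, and compound 1 still gives 14700 nM. On that basis, no change beyond the scatter is expected in this assay. The estimated step is a 1.2-fold lower number from compound 2 to compound 3 (0.07 log units; within the scatter), which is small. For compound 3 the expected value is 15000 nM, with an estimated range from 7500 nM to 30000 nM.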

Compound 3, half-maximal inhibitory concentration: 10300 nM
The estimate for compound 3 lay 1.5-fold (0.16 log units) above the measured number, and the stated range covers the measured number.
By their numbers in this assay, from the lowest: compounds 3, 1 and 2 (each within the scatter of the next).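

Compounds 1 and 2 differ in two places, so they could not show what either change does alone; compound 3 separates the two. In this assay, bromo in place of hydrogen on this aromatic carbon, ortho to a large group, gives a 1.7-fold lower number from compound 2 to compound 3 (0.24 log units; within the scatter), while hydrogen in place of the methyl gives a 1.4-fold lower number from compound 1 to compound 3 (0.15 log units; within the scatter), so neither single change moves the number beyond the scatter. No evidence here offers a reason for these small steps. On these data alone, whether an amine or a carboxylic acid on the bromo-bearing carbon would give a larger step remains open.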